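Permeability at the Limit: From Compound 2 to Compound 4

This account rests on a few compounds, and the source may have more. Where it says the series, first, only, none or still open, it means among the compounds named here.

Compound 1, `CNC(=O)c1cc(Oc2ccc3nc(Nc4ccccc4)ncc3c2)ccn1`: < 1 10^-6 cm/s
Compound 2, `CNC(=O)c1cc(Oc2ccc3nc(Nc4cccc(C(C)(C)C)c4)ncc3c2)ccn1`: < 1 10^-6 cm/s
Compound 3, `CNC(=O)c1cc(Oc2ccc3nc(Nc4cccc(C(C)(C)C)c4)cnc3c2)ccn1`: < 1 10^-6 cm/s

In an ADME assay on Caco-2 cells (Homo sapiens) for permeability, in the apical to basolateral direction (on this read-out lower numbers stand for lower permeability and higher numbers for higher permeability), compound 1 gives only a limit of the assay, < 1 10^-6 cm/s. Compound 2 likewise gives only a limit, < 1 10^-6 cm/s. Compound 3 also gives only a limit, < 1 10^-6 cm/s. The step that the two limits leave unreadable from compound 1 to compound 2 is thus unreadable, and the three values carry no more than the limit of < 1 10^-6 cm/s in this assay, at which 3 of the 3 values shown sit.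

Compound 4, `CNC(=O)c1cc(Oc2ccc3nc(Nc4ccccc4Br)ncc3c2)ccn1`, differs from compound 2 by 2-bromophenyl in place of 3-(tert-butyl)phenyl on a nitrogen on an aromatic ring. Among the compounds with values here, no measured step reads on this change; compound 2 stands at the limit and nothing shows movement away from it. The step that the limit leaves unreadable from compound 2 to compound 4 in this assay is therefore expected to be none beyond the scatter. Compound 4 is estimated at 0.5 10^-6 cm/s, between 0.1 10^-6 cm/s and 2 10^-6 cm/s.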

Compound 4, apparent permeability: < 1 10^-6 cm/s
Compound 4: no number, only a limit; the forecaster's own chance of this, stated with the estimate: 70%; the middle value does not contradict the limit.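

Compound 4 also gives only a limit of the assay, so no step among compound 1, compound 2 and compound 4 can be read: the limit of < 1 10^-6 cm/s in this assay, at which 4 of the 4 values shown sit.

The compounds shown leave open whether any of these changes moves the result in this assay, and where each compound's true value lies.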